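Series notes: methoxy ortho to a phenoxy group

The source may report more compounds than this note shows. Statements on the series, on what has been measured and on what is new or still open speak of the compounds shown alone.

Compound 1 `Cc1ccccc1-n1nc(C)c2c1NC(=O)[C@H](C)S[C@@H]2c1ccc(Oc2ccccc2)cc1` gives 118% in an assay on isolated protein for agonist activity at Bile acid receptor (Homo sapiens), read by AlphaScreen, with a stated time of 30 min (a lower number here means a smaller maximal response, a higher number a larger maximal response), the highest of the three measured numbers. Compound 2 `CCOc1cccc(-c2ccc([C@H]3S[C@@H](C)C(=O)Nc4c3c(C)nn4-c3ccccc3C)cc2)c1` gives 13% and compound 3 `Cc1ccccc1-n1nc(C)c2c1NC(=O)[C@H](C)S[C@@H]2c1ccc(-c2ccoc2)cc1` gives 40%; the steps of a number 105 percentage points lower from compound 1 to compound 2 (beyond the scatter) and a number 78 percentage points lower from compound 1 to compound 3 (beyond the scatter) are both large, and both concern the phenoxy group itself. Compound 4 `COc1cc([C@H]2S[C@@H](C)C(=O)Nc3c2c(C)nn3-c2ccccc2C)ccc1Oc1ccccc1` differs from compound 1 by methoxy in place of hydrogen on an aromatic carbon, with the phenoxy group kept. Among the measured compounds shown here, no measured step adds a methoxy on this ring, so those two steps give only indirect guidance: the region tolerates change poorly, but the present change is smaller. A step of a number 23 percentage points lower from compound 1 to compound 4 (beyond the scatter) is expected, modest at most or none beyond the scatter. Compound 4 is estimated at 95%, with a range from 45% to 125%.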

Compound 4, largest response reached (reported as efficacy), in percent of the reference or control that the assay uses: 130%
Estimate against measurement, compound 4: 35 percentage points below; measured number above the stated range.
By their numbers in this assay, from the lowest: compound 2; then compound 3; then compound 1; then compound 4.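

Methoxy in place of hydrogen, ortho to a phenoxy group, brings a number 12 percentage points higher from compound 1 to compound 4 (beyond the scatter) in this assay. The earlier steps shown here replaced the phenoxy group itself and lowered the number, whereas this step keeps that group and shows that the same ring accepts an added methoxy with a modest rise. No available evidence bears on the reason for this rise.

On these data alone, whether a fluorine atom, a hydroxy group or a longer alkoxy chain at this place would give a similar result remains open. The compounds shown also leave open whether methoxy would have any such effect without the phenoxy group.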